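The source may hold more compounds than are shown below. What is called first, only, known or untested is meant among the compounds shown, and "the series" means these compounds.

Compound 1, `CN1CCN(c2nc3cccc(Cl)c3o2)CC1`: 5.5
Compound 2, `CN1CCN(c2nc3cc([N+](=O)[O-])ccc3o2)CC1`: 6.1

Of the compounds shown here, two have been measured in a functional assay on ileum (strain Hartley) for agonist activity at 5-hydroxytryptamine receptor 3A (Cavia porcellus); a higher number here means a more potent compound, by a factor of ten per unit of this negative logarithm, a lower number a less potent compound. Compound 2 gives 6.1, the higher of the two numbers. Compound 1 gives 5.5, and that gap lies beyond the usual scatter, so compound 2 is the more potent of the pair. Compound 3, `CN1CCN(c2nc3cc(N)ccc3o2)CC1`, has not yet been measured. It differs from compound 2 in one place: amino in place of nitro on an aromatic carbon. Among the compounds with values here, no measured pair shows what this change does, so its direction is not settled by the data. Since compound 2 already stands at 6.1, the top of the small set, a drop of moderate size is expected for compound 3 in this assay. Compound 3 is expected to give about 5.3, somewhere between 4.5 and 6.1. The step this estimate implies is expected to be a number 0.80 log units lower from compound 2 to compound 3 (beyond the scatter).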

Compound 3, negative logarithm of the half-maximal effective concentration: 4.97
For compound 3 the middle estimate is 0.33 log units above the measured one; the measured number falls inside the stated range.
By their numbers in this assay, from the lowest: compound 3; then compound 1; then compound 2.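

Amino in place of nitro on this aromatic carbon gives a number 1.13 log units lower from compound 2 to compound 3 (beyond the scatter) in this assay and provides the first measured change in a single place in this set. The large size of this step shows that the number in this assay depends strongly on which of these two groups sits at this position, with nitro giving the higher number. No available measurement accounts for this drop.

On these data alone, it remains open how other groups on this same carbon, such as a nitrile, a methoxy group or an acetamide, would compare with nitro and amino. As far as these compounds go, it is also open whether the same exchange would produce a step of similar size on another carbon of the six-membered ring.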